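Piperazinyl acetamides at the dopamine D4 receptor: next step

The source may report more compounds than this note shows. Statements on the series, on what has been measured and on what is new or still open speak of the compounds shown alone.

Measured so far:
compound 1 `CCc1cccc(NC(=O)CN2CCN(c3ccc(Cl)cn3)CC2)c1` — 172 nM
compound 2 `O=C(CN1CCN(c2ccccn2)CC1)Nc1cncnc1` — 39300 nM
compound 3 `Cc1cccc(NC(=O)CN2CCN(c3ncccn3)CC2)c1` — 318 nM

In an assay on HEK293 cells for displacement of a labelled ligand from D(4) dopamine receptor (Homo sapiens), read by scintillation counting, with a stated time of 60 min (a higher number here means a weaker inhibitor, a lower number a stronger inhibitor), compound 3 gives 318 nM, the second highest of the three numbers. Compound 1 sits nearest with a lower number, inside the scatter of repeated runs, so no order between the two can be claimed. Compound 2 lies furthest away, with a far higher number that is well beyond the scatter.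

Compound 4 `Cc1cccc(NC(=O)CN2CCN(c3ccc(Cl)cn3)CC2)c1` has not been measured. It differs from compound 3 in one place: 5-chloropyridin-2-yl in place of pyrimidin-2-yl on an amine nitrogen in a ring. Compound 1 already carries the same group on the ring nitrogen and gives 172 nM, so in this assay the step from compound 3 to compound 4 is expected to be small, toward a lower number, and probably not beyond the scatter a 2.0-fold lower number from compound 3 to compound 4 (0.30 log units; within the scatter). Compound 4 is estimated at 160 nM, within 55 nM to 480 nM.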

Compound 4, inhibition constant: 95 nM
For compound 4 the middle estimate is 1.7-fold (0.23 log units) above the measured one, within the range that was stated.
By their numbers in this assay, from the lowest: compounds 4, 1 and 3 (each within the scatter of the next, the first and the last beyond it); then compound 2.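

In this assay, 5-chloropyridin-2-yl in place of pyrimidin-2-yl on the ring nitrogen gives a 3.3-fold lower number from compound 3 to compound 4 (0.52 log units; beyond the scatter) as a modest step, so this position responds to the change when nothing else in the structure differs. Hydrogen in place of methyl on the saturated chain carbon bound to an aromatic carbon gives a 1.8-fold lower number from compound 1 to compound 4 (0.26 log units; within the scatter) and no order can be claimed for that pair. No measured evidence bears on the reason for either step.

On these data alone, the change swaps the ring and adds the chlorine at once, so the share of each stays open. As far as these compounds go, whether fluorine or methoxy at the place of the chlorine would keep the step also stays open.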